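Swapping a five-membered lactam for a six-membered one

This account rests on a few compounds, and the source may have more. Where it says the series, first, only, none or still open, it means among the compounds named here.

Measured compounds:
compound 1 `CC(=O)N1CCc2cc(-c3cccc4c3CCCC4)cc(N3CCCC3=O)c21` gives 271000 nM;
compound 2 `C[C@]1(CS(=O)(=O)N2CC=C(C#Cc3cccc(N4CCCCC4=O)c3)CC2)NC(=O)NC1=O` gives 89000 nM;
compound 3 `CN1CCN(c2cnc(NCc3c(F)ccc4c3CCO4)n3cnnc23)C1=O` gives 641000 nM.

These three were tested in a physicochemical assay for solubility, at pH 7.4; a higher number here means a more soluble compound, a lower number a less soluble compound. Compound 3 stands highest of the three; compound 1 is the nearest to it, and compound 2 the furthest, both gaps lying beyond the scatter of repeats. Compound 4 `O=C1CCCCN1c1cnc(NCc2c(F)ccc3c2CCO3)n2cnnc12` has not yet been measured in this assay. It differs from compound 3 in one place: 2-oxopiperidin-1-yl in place of 3-methyl-2-oxoimidazolidin-1-yl on an aromatic carbon. Among the measured compounds shown here, no pair of measured compounds shows this exact change, so its effect is unknown. A modest downward step is expected, because compound 2, the compound carrying the same 2-oxopiperidin-1-yl group, gave 89000 nM. The step is estimated as a 2.1-fold lower number from compound 3 to compound 4 (0.33 log units; beyond the scatter). Compound 4 is therefore expected to give about 300000 nM, with a likely range from 100000 nM to 700000 nM.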

Compound 4, solubility: 351000 nM
Compound 4: the middle estimate sits 1.2-fold (0.07 log units) below what was measured; low and high end bracket the measured number.
By their numbers in this assay, from the lowest: compound 2; then compounds 1, 4 and 3 (each within the scatter of the next, the first and the last beyond it).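

In this assay, replacing 3-methyl-2-oxoimidazolidin-1-yl with 2-oxopiperidin-1-yl on this aromatic carbon gives a 1.8-fold lower number from compound 3 to compound 4 (0.26 log units; within the scatter) on the shared core. At this position, then, the measurement does not separate the five-membered ring with two hetero atoms from the six-membered ring with one. Nothing shown gives a measured reason for this result.

On these data alone, whether a morpholine ring or an open-chain acetamide here would also stay within the scatter of compound 3 remains open. So does whether the same swap behaves alike on a different core.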